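The source may hold more compounds than are shown below. What is called first, only, known or untested is meant among the compounds shown, and "the series" means these compounds.

Working notes on the series. Three analogues on a shared core have been measured: compound 1 `CCCc1cc(C(C)=O)c(O)cc1OCCCCC#N`, compound 2 `CCCCCc1cc(C(C)=O)c(O)cc1OCCCCC#N` and compound 3 `COCc1cc(C(C)=O)c(O)cc1OCCCCCCC#N`. In an assay on isolated protein for binding affinity to leukotriene B4 receptor 1 (Homo sapiens), tested at 1 uM (on this read-out lower numbers stand for less inhibition and higher numbers for more inhibition at the one concentration tested (going by the name of the read-out)), compound 1 gives 37%, compound 2 gives 14% and compound 3 gives 7%. For the measured compounds named here, compound 2 therefore stands second of the three numbers, within the scatter of compound 3, while the only single-point step measured is a number 23 percentage points lower from compound 1 to compound 2 (beyond the scatter). Compound 4 `CC(=O)c1cc(C(C)=O)c(OCCCCC#N)cc1O` is not yet measured; it differs from compound 2 by acetyl in place of pentyl on an aromatic carbon. Going by the values given here, no measured step exchanges a chain for acetyl at this aromatic carbon, and the one step in hand, a number 23 percentage points lower from compound 1 to compound 2 (beyond the scatter), concerns chain length only, so it gives no direct guide. A change not beyond the scatter is expected, a number 1 percentage points higher from compound 2 to compound 4 (within the scatter). Compound 4 is estimated at 15%, range 0% to 40%.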

Compound 4, a percentage reported as inhibition, at one concentration (the size of the read-out at that concentration, not a potency): 0%
Estimate against measurement, compound 4: 15 percentage points above; low and high end bracket the measured number.
By their numbers in this assay, from the lowest: compounds 4, 3 and 2 (each within the scatter of the next, the first and the last beyond it); then compound 1.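

At the aromatic carbon para to a hydroxy group, the exchange of a chain for acetyl gives a number 14 percentage points lower from compound 2 to compound 4 (beyond the scatter) and a number 37 percentage points lower from compound 1 to compound 4 (beyond the scatter) in this assay, so this carbon responds to the type of group as well as to chain length. Among the three groups shown at this carbon, propyl gives the highest number, beyond the scatter of both pentyl and acetyl. Nothing available here bears on the origin of these steps. Still open, on these data alone, is how an ethyl chain, an amine or a carboxylic acid at this carbon would read. Also open, as far as these compounds go, is whether acetyl has the same effect with the longer chain on oxygen.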